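The compounds below may be only part of what the source reports. "The series", "measured", "known", "first", "only" and "open" are said of these compounds alone.

Series notes. Compound 1 `CC(C)NC(=O)[C@H]1CC[C@@H](n2/c(=N/C(=O)c3ccc(F)c(F)c3)[nH]c3ccc(CN4CCC(C(C)(C)O)CC4)cc32)CC1` is the reference point. In an in vitro ADME assay on microsomes from liver (Homo sapiens) for metabolic stability (on this read-out higher numbers stand for fast clearance and lower numbers for slow clearance), compound 1 gives 60 mL.min-1.g-1, the lowest of the three numbers in hand. Compound 3 `CCOC(=O)[C@H]1CC[C@@H](n2/c(=N/C(=O)c3ccccc3)[nH]c3ccc(CN4CCCCC4)cc32)CC1` gives 222 mL.min-1.g-1 in this assay, a step beyond the scatter from compound 1. Compound 2 `CC(C)NC(=O)[C@H]1CC[C@@H](n2/c(=N/C(=O)c3ccc(F)cc3)[nH]c3ccc(CN4CCCCC4)cc32)CC1` gives 302 mL.min-1.g-1 in this assay, the furthest from compound 1 and also beyond the scatter. No two of these three compounds differ in one place only, so no single change among them can be read off.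

Compound 4 `CC(C)NC(=O)[C@H]1CC[C@@H](n2/c(=N/C(=O)c3cccnc3)[nH]c3ccc(CN4CCC(C(C)(C)O)CC4)cc32)CC1` departs from compound 1 as follows: pyridin-3-yl in place of 3,4-difluorophenyl on a carbonyl carbon. Nothing measured here bears directly on that change. For compound 4 the step expected in this assay is a 1.3-fold lower number from compound 1 to compound 4 (0.12 log units; within the scatter), toward slower clearance but not beyond the scatter. Compound 4 is thus estimated at 45 mL.min-1.g-1, with a range from 20 mL.min-1.g-1 to 110 mL.min-1.g-1.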

Compound 4, intrinsic clearance in microsomes: 47 mL.min-1.g-1
For compound 4 the middle estimate is 1.0-fold (0.02 log units) below the measured one; measured number inside the range.
By their numbers in this assay, from the lowest: compounds 4 and 1 (each within the scatter of the next); then compounds 3 and 2 (each within the scatter of the next).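

Going by these compounds alone, this is the first pair that differs in one place: pyridin-3-yl in place of 3,4-difluorophenyl on a carbonyl carbon gives a 1.3-fold lower number from compound 1 to compound 4 (0.11 log units; within the scatter) in this assay. At this position, the two aryl groups cannot be told apart on this read-out. No measurement on hand accounts for this result.

From the compounds shown here alone, whether pyridin-4-yl or an open propyl chain on the same carbonyl carbon would read alike stays open. Within the data shown here, no pair yet isolates any change elsewhere in the molecule.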